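The source may hold more compounds than are shown below. What is called first, only, known or untested is meant among the compounds shown, and "the series" means these compounds.

Measured so far:
compound 1 `Cc1nc(N)c2nn(Cc3ccccc3)cc2n1`: 1%
compound 2 `COc1ccccc1-n1cc2nc(-c3ccc(C)o3)nc(N)c2n1`: 1%
compound 3 `Nc1nc(CCCc2ccccc2)nc2cn(-c3ccccc3F)nc12`: 25%

In an assay on CHO cells for displacement of a labelled ligand from adenosine receptor A1 (Homo sapiens), read by scintillation counting, with a stated time of 120 min, tested at 1 uM (on this read-out higher numbers stand for more inhibition at the one concentration tested (going by the name of the read-out) and lower numbers for less inhibition), compound 1 gives 1%. On that number compound 1 stands level with compound 2, which gives 1% in this assay; together they are the lowest of the three values, and the gap between them is no change at the digits shown, within the scatter. The furthest value is that of compound 3, which gives 25% in this assay, a number higher than that of compound 1 by more than the scatter.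

Compound 4 `Nc1nc(-c2ccco2)nc2cn(Cc3ccccc3)nc12` has not yet been measured in this assay. It is derived from compound 1 by one change: furan-2-yl in place of methyl on an aromatic carbon. Within the data shown here, no step between two measured compounds with this same change is available, so the account rests on the values above and on the change itself. The expected step of a number 7 percentage points higher from compound 1 to compound 4 (within the scatter) is small, in the upward direction at most, and may well lie within the scatter. Compound 4 is therefore estimated to give 8% in this assay, with a range from 0% to 28%.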

Compound 4, a percentage reported as inhibition, at one concentration (the size of the read-out at that concentration, not a potency): 32%
Compound 4: the middle estimate sits 24 percentage points below what was measured, outside the stated range (above it).
By their numbers in this assay, from the lowest: compounds 1 and 2 (each within the scatter of the next); then compounds 3 and 4 (each within the scatter of the next).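

In this assay, furan-2-yl in place of methyl on the aromatic carbon between two ring nitrogen atoms goes with a number 31 percentage points higher from compound 1 to compound 4 (beyond the scatter). Among these compounds, this is the first reading of a single change in the set, as the earlier compounds differ from one another in more than one place, and it shows that the group on this carbon can move the inhibition at the one concentration tested beyond the scatter. No measurement at hand explains this step.

One step cannot tell whether the gain follows from the added five-membered aromatic ring, its ring oxygen or simply the larger group. As far as these compounds go, how a thiophen-2-yl, a phenyl or an amine on this carbon would compare with furan-2-yl remains open, as does whether the step would hold with a group other than the benzyl of compound 4 on the ring nitrogen.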